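The compounds below may be only part of what the source reports. "The series", "measured", "known", "first", "only" and "open" are said of these compounds alone.

Compound 1 `O=C1C(NC2CCCC2)=CC(=O)c2c1nc1n2[C@H]2OC[C@@H](O)[C@H]2OC1` carries a cyclopentylamino group on its core. In a functional assay on MCF7 cells (Homo sapiens) for inhibition, read by sulforhodamine B assay (on this read-out lower numbers stand for stronger inhibition and higher numbers for weaker inhibition), compound 1 gives > 16000 nM, which is a limit of the assay rather than a number. Compound 2 `COc1ccccc1NC1=CC(=O)c2c(nc3n2[C@H]2OC[C@@H](O)[C@H]2OC3)C1=O` differs by 2-methoxyphenyl in place of cyclopentyl on an amine nitrogen and gives 6580 nM in this assay. That change made an at least 2.4-fold lower number from compound 1 to compound 2 (0.38 log units; beyond the scatter); because compound 1 sits at the limit of > 16000 nM in this assay, at which 2 of the 3 values shown sit, only the lower bound of the step is known. Compound 3 `O=C1C=C(NC2CCCC2)C(=O)c2c1nc1n2[C@H]2OC[C@@H](O)[C@H]2OC1` has the same atoms as compound 1 joined differently, and the difference between the two cores is not broken down here. In this assay compound 3 gives > 16000 nM, again a limit and not a number. Compound 4 `COc1ccccc1NC1=CC(=O)c2nc3n(c2C1=O)[C@H]1OC[C@@H](O)[C@H]1OC3` is not yet measured; it differs from compound 3 by 2-methoxyphenyl in place of cyclopentyl on an amine nitrogen, and the place of the change is the same as before, so this is the same change. The account expects an at least 2.0-fold lower number from compound 3 to compound 4 (0.30 log units; that floor lies within the scatter) for compound 4, resting on the step from compound 1 to compound 2, an at least 2.4-fold lower number from compound 1 to compound 2 (0.38 log units; beyond the scatter). Compound 4 is therefore estimated at 8000 nM in this assay, between 3000 nM and 30000 nM.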

Compound 4, half-maximal inhibitory concentration: > 4000 nM
Compound 4 was reported as a limit (the forecaster's own chance of this, stated with the estimate: 35%); the middle value does not contradict the limit.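

The step between compound 3 and compound 4 cannot be read, since each of the two values in this assay is a limit and not a number. The compounds shown leave open whether 2-methoxyphenyl in place of cyclopentyl on an amine nitrogen lowers the number on the core of compound 3 as it does on the core of compound 1.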